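This account rests on a few compounds, and the source may have more. Where it says the series, first, only, none or still open, it means among the compounds named here.

Measured so far:
compound 1 `COc1cc(OC)c(-c2coc3cc(OCC=C(C)C)ccc3c2=O)cc1OC`: 680 nM
compound 2 `COc1cccc(C(=O)Oc2ccc3c(=O)c(-c4cc(OC)c(OC)cc4OC)coc3c2)c1`: a limit only
compound 3 `COc1cc(OC)c(-c2coc3cc(OCc4ccccc4F)ccc3c2=O)cc1OC`: 2900 nM

In a functional assay on HCT-116 cells (Homo sapiens) for antiproliferative activity, read by MTT assay, with a stated time of 24 h (a lower number here means a stronger inhibitor, a higher number a weaker inhibitor), compound 1 gives 680 nM. Compound 2 reaches only the limit of this assay, > 10000 nM. Compound 3 gives 2900 nM, the higher of the two numbers shown, with a 4.3-fold higher number from compound 1 to compound 3 (0.63 log units; beyond the scatter). Compound 4 `COc1cc(OC)c(-c2coc3cc(OCc4ccccc4Cl)ccc3c2=O)cc1OC` differs from compound 3 by chloro in place of fluoro on an aromatic carbon. Among the measured compounds shown here, no measured step swaps one halogen for another; the steps that touch this part of the molecule, a 4.3-fold higher number from compound 1 to compound 3 (0.63 log units; beyond the scatter) and an at least 3.4-fold lower number from compound 2 to compound 3 (0.53 log units; beyond the scatter), exchange the whole group on the oxygen and are much larger changes than this one. The expected step is therefore small, within the scatter: a 1.2-fold lower number from compound 3 to compound 4 (0.06 log units; within the scatter). Compound 4 is expected to give about 2500 nM, between 1000 nM and 6000 nM.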

Compound 4, half-maximal inhibitory concentration: 2450 nM
The estimate for compound 4 lay 1.0-fold (0.01 log units) above the measured number; low and high end bracket the measured number.
By their numbers in this assay, from the lowest: compound 1; then compounds 4 and 3 (each within the scatter of the next). At a limit, above all of these: compound 2.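

Fluoro and chloro on this aromatic carbon cannot be told apart in this assay, with a 1.2-fold lower number from compound 3 to compound 4 (0.07 log units; within the scatter). The gap to the 3-methylbut-2-en-1-yl group of compound 1 therefore holds with either halogen, with a 3.6-fold higher number from compound 1 to compound 4 (0.56 log units; beyond the scatter), and 2-chlorobenzyl also stands clear of the (3-methoxyphenyl)carbonyl group, with an at least 4.0-fold lower number from compound 2 to compound 4 (0.61 log units; beyond the scatter). Compound 2 gives only a limit, not a number: the limit of > 10000 nM in this assay, at which 1 of the 4 values shown sits.

Going by these compounds, what a bromo, a methoxy or an amine on this aromatic carbon would do stays open. So does whether any benzyl group on the oxygen can match compound 1.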